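This account rests on a few compounds, and the source may have more. Where it says the series, first, only, none or still open, it means among the compounds named here.

Compound 1 `O=C(N[C@H]1CN(S(=O)(=O)c2ccccc2)C[C@@H]1C(=O)N[C@H]1CCCNC1)c1cc(C2CC2)n[nH]1` gives < 3 mL.min-1.g-1 in an ADME assay on microsomes from liver (Homo sapiens) for metabolic stability (a higher number here means faster removal of the compound, a lower number slower removal), which is a limit of the assay and not a number.
Compound 2 `O=C(N[C@H]1CN(S(=O)(=O)c2ccccc2)C[C@@H]1C(=O)N[C@H]1CCCNC1)c1cn(C2CC2)cn1` gives < 3 mL.min-1.g-1 in this assay, again a limit rather than a number.
Compound 3 `O=C(N[C@H]1CN(S(=O)(=O)c2ccccc2)C[C@@H]1C(=O)N[C@H]1CCCNC1)c1cc(-c2ccccc2Cl)on1` gives < 3 mL.min-1.g-1 in this assay, also a limit rather than a number.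

All three compounds share one core and differ only in the group attached to one carbonyl carbon. The steps between them, a step that the two limits leave unreadable from compound 1 to compound 2, a step that the two limits leave unreadable from compound 1 to compound 3 and a step that the two limits leave unreadable from compound 2 to compound 3, cannot be read, because of the limit of < 3 mL.min-1.g-1 in this assay, at which 3 of the 3 values shown sit. Compound 3 therefore stands at the same limit as the other two, and nothing separates them on these numbers.

Among the measured compounds shown here, compound 4 `O=C(N[C@H]1CN(S(=O)(=O)c2ccccc2)C[C@@H]1C(=O)N1C[C@H]2CCNC[C@H]21)c1cc(-c2ccccc2Cl)on1` keeps the group of compound 3 on that first carbonyl carbon and changes a different carbonyl carbon, the one whose other neighbour is a saturated ring carbon: a group of 8 heavy atoms (6 carbon, 2 nitrogen; one four-membered non-aromatic ring with 1 hetero atom, one six-membered non-aromatic ring with 1 hetero atom) in place of a group of 7 heavy atoms (5 carbon, 2 nitrogen; one six-membered non-aromatic ring with 1 hetero atom), on a carbonyl carbon. For the measured compounds named here, none of the measured steps touches this part of the molecule, and all three are unreadable in any case. Going by the values given here, no measured step therefore bears on this change, and there is no basis for expecting a shift beyond the scatter in this assay. Compound 4 is expected to sit at 3 mL.min-1.g-1, with a range from 1 mL.min-1.g-1 to 8 mL.min-1.g-1, most likely reported once more as a limit. The step expected is a number no lower from compound 3 to compound 4 (the limit leaves the size open), none beyond the scatter.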

Compound 4, intrinsic clearance in microsomes: 7.3 mL.min-1.g-1
The estimate for compound 4 lay 2.4-fold (0.39 log units) below the measured number; low and high end bracket the measured number.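

This result shows that the carbonyl carbon whose other neighbour is a saturated ring carbon is a place where this assay can respond: replacing the (piperidin-3-yl)amino group with the group holding a four-membered and a six-membered non-aromatic ring gives an at least 2.4-fold higher number from compound 3 to compound 4 (0.38 log units; beyond the scatter). Because compound 3 is reported only as a limit, this step has a floor but no known upper size, and the true gap could be larger. Compound 4 also gives the first actual number in the series, whereas the three steps among the earlier compounds, which all changed the other carbonyl carbon, cannot be read, because their values all sit at one limit: the limit of < 3 mL.min-1.g-1 in this assay, at which 3 of the 4 values shown sit.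

The compounds shown leave open whether the four-membered ring, the added stereocentre or the loss of a hydrogen-bond donor accounts for the step, and a simpler group such as pyrrolidin-3-ylamino or piperazin-1-yl at this place could help to separate these. They also leave open whether the same replacement gives a similar step when the 3-cyclopropyl-1H-pyrazol-5-yl group of compound 1 sits on the first carbonyl carbon.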